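Swapping a carboxy group for a methylcarbamoyl group

A few compounds are considered here, and "the series" means these few. Any claim that something is new, unique, unknown or untested is made for them only; others in the source may bear on it.

In a functional assay on A549 cells (Homo sapiens) for inhibition, read by sulforhodamine B assay, with a stated time of 72 h (a higher number here means a weaker inhibitor of growth, a lower number a stronger inhibitor of growth), compound 1 `CCOC(=O)/C=C/c1ccncc1-c1ccc2c(cnn2C)c1` gives 5030 nM. Compound 2 `Cn1ncc2cc(-c3cnccc3/C=C/C(=O)O)ccc21` gives > 10000 nM, which is a limit of the assay and not a number.

Compound 3 `CNC(=O)/C=C/c1ccncc1-c1ccc2c(cnn2C)c1` differs from compound 2 in one place: methylamino in place of hydroxy on a carbonyl carbon. This puts methylamino in place of hydroxy on a carbonyl carbon, so carboxy becomes methylcarbamoyl. Going by the values given here, only one measured step touches this same end of the molecule, where hydrogen replaces ethyl: an at least 1.9-fold higher number from compound 1 to compound 2 (0.29 log units; that floor lies within the scatter). That step is not shown to exceed the scatter, so it offers only a weak guide. It also involves a different group from the one entering here.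

A modest move towards a lower number in this assay is therefore expected, though a step no larger than the scatter and another reading at the limit both remain plausible. The expected change is an at least 1.4-fold lower number from compound 2 to compound 3 (0.15 log units; that floor lies within the scatter). The estimate for compound 3 is 7000 nM, with an expected range from 2500 nM to 20000 nM.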

Compound 3, concentration for 50% growth inhibition: > 10000 nM
Compound 3: a limit, no number; the forecaster's own chance of this, stated with the estimate: 40%; at least 1.4-fold (0.15 log units) between middle value and limit.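

In this assay compound 3 gives > 10000 nM, which is a limit of the assay and not a number. Going from ethoxy to methylamino on the carbonyl carbon gives an at least 1.9-fold higher number from compound 1 to compound 3 (0.29 log units; that floor lies within the scatter), so no real loss against compound 1 is shown, yet ethoxy remains the only group at this carbonyl carbon with a readable number. The step between compound 2 and compound 3 cannot be read because both compounds give only a limit, so methylamino and hydroxy cannot be ranked against each other: the limit of > 10000 nM in this assay, at which 2 of the 3 values shown sit.

The compounds shown leave open how far compound 2 and compound 3 actually lie beyond that limit. Also open, on these data alone, is whether any group on this carbonyl carbon can give a clearly lower number than compound 1, which gives 5030 nM. A longer alkoxy chain such as butoxy, or a dimethylamino group in place of methylamino, would test whether the readable number depends on an ester or can also be reached with an amide.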